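The source may hold more compounds than are shown below. What is called first, only, known or untested is meant among the compounds shown, and "the series" means these compounds.

Two compounds from this series have been examined in an assay on cells for agonist activity at D(4) dopamine receptor (Homo sapiens), read by luminescence and beta-arrestin recruitment, with a stated time of 90 min; a higher number here means a larger maximal response, a lower number a smaller maximal response. Compound 1, with the structure `Cc1ccc(C2CCN(CC(=O)Nc3cccc(C)c3)CC2)cc1`, is recorded in this assay as "not active" (no number reported), with no number attached to it. Among the compounds with values here, compound 2, with the structure `Cc1cccc(NC(=O)CN2CCC(c3ccccc3)CC2)c1`, is the only member of the pair for which a maximal response is given: in this assay compound 2 reaches 14%, a modest level that places it as the sole reference point among the numbers available here.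

The next compound, compound 3, has the structure `Cc1cccc(NC(=O)CN2CCC(c3ccc(Cl)cc3)CC2)c1` and has not yet been tested in this assay. It differs from compound 2 in one place: chloro in place of hydrogen on an aromatic carbon. Within the data shown here, no measured pair in this set carries the same change, so there is no recorded step on which to rest a firm prediction; what can be said comes only from the single value of compound 2 and the small size of the change.

Compound 3 is expected to stay close to compound 2, with a step of a number 6 percentage points higher from compound 2 to compound 3 (within the scatter) that may not clear the usual scatter of repeated runs. The estimate for compound 3 in this assay is 20%, with a likely range from 5% to 40%.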

Compound 3, largest response reached (Emax), in percent of the reference or control that the assay uses: "not active" (no number reported)
Compound 3 has no reported number here, so the estimate cannot be set against anything.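

In this assay, within the data shown here, compound 3 is recorded as "not active" (no number reported) and so no step from compound 2 to compound 3 can be read. Nothing available here accounts for this result. The compounds shown leave open how the change from phenyl to 4-chlorophenyl affects the maximal response, as no numerical comparison exists for it.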